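Cytotoxicity notes: replacing the methoxyphenyl group of compound 2

This account rests on a few compounds, and the source may have more. Where it says the series, first, only, none or still open, it means among the compounds named here.

Compound 1 `COc1ccc(-c2nc(CS(=O)(=O)c3cccc(Cl)c3)nc3ccsc23)cn1`: in an ADME assay on cells (Homo sapiens) for cytotoxicity, read by resazurin assay, with a stated time of 5 days (on this read-out higher numbers stand for lower toxicity in this test and lower numbers for higher toxicity in this test), compound 1 gives > 10000 nM, which is a limit of the assay, not a number.
Compound 2 `COc1ccc(-c2nc(CS(=O)(=O)c3cccc(Cl)c3)nc3ccsc23)cc1`: in this assay compound 2 gives 69000 nM.

Going by the values given here, compound 2 holds the only number in this assay; the other value shown is a limit. The step that the limit leaves unreadable from compound 1 to compound 2 therefore has no readable size, because of the limit of > 10000 nM in this assay, at which 1 of the 2 values shown sits. Compound 3 `O=c1ccc(-c2nc(CS(=O)(=O)c3cccc(Cl)c3)nc3ccsc23)c[nH]1` is not yet measured. Its change from compound 2 is a group of 7 heavy atoms (5 carbon, 1 nitrogen, 1 oxygen; one six-membered aromatic ring with 1 hetero atom) in place of a group of 8 heavy atoms (7 carbon, 1 oxygen; one six-membered aromatic ring of carbon only), on an aromatic carbon. Among the compounds with values here, no measured step bears directly on this change, and the one step available gives no size, so no guidance exists for a step beyond the scatter in either direction. Compound 3 is therefore expected to stay close to compound 2, with an expected step of no change at the digits printed from compound 2 to compound 3 (within the scatter) in this assay within the scatter. The estimate for compound 3 in this assay is 69000 nM, expected between 20000 nM and 200000 nM.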

Compound 3, half-maximal cytotoxic concentration: > 50000 nM
Compound 3: a limit, no number; the forecaster's own chance of this, stated with the estimate: 20%; the middle value does not contradict the limit.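

In this assay, going by these compounds alone, compound 3 gives > 50000 nM as a limit and not a number, and no step among compound 1, compound 2 and compound 3 can be read. Going by these compounds, whether these groups on the aromatic carbon differ beyond the scatter stays open.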